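This account rests on a few compounds, and the source may have more. Where it says the series, first, only, none or still open, it means among the compounds named here.

Measured in an ADME assay (liver) for metabolic stability, with Liver microsome (Homo sapiens) as the target, read by LC-MS, using microsomes and NADPH, with a stated time of 5 min, at 37 degrees C; on this read-out lower numbers stand for slow clearance and higher numbers for fast clearance:
- compound 1 `CCn1c([C@@H](C)NS(=O)(=O)c2ccc(Cl)cc2)nc2ccc(CO)cc21`: 84 mL.min-1.g-1
- compound 2 `CCn1c([C@@H](C)NS(=O)(=O)c2ccccc2)nc2ccc(C(F)(F)F)cc21`: 14 mL.min-1.g-1
- compound 3 `CCn1c([C@@H](C)NS(=O)(=O)c2ccc(F)cc2)nc2ccc(C(F)(F)F)cc21`: 26 mL.min-1.g-1

Compound 3 at 26 mL.min-1.g-1 lies within the scatter of compound 2 at 14 mL.min-1.g-1, and both numbers are well under that of compound 1 at 84 mL.min-1.g-1.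

The next compound is compound 4 `CCn1c([C@@H](C)NS(=O)(=O)c2cccc(Cl)c2)nc2ccc(C(F)(F)F)cc21`, and the change is 3-chlorophenyl in place of 4-fluorophenyl on a sulfonyl sulfur. The trifluoromethyl-bearing core of compound 3 stays in place.

Among the compounds with values here, only one measured step touches this aryl group: a 1.9-fold higher number from compound 2 to compound 3 (0.27 log units; within the scatter), which stays within the scatter. Compound 1 also has a chlorine on its aryl group, but its core differs as well, so its number says little about this change. Within the data shown here, no measured step isolates chlorine on the trifluoromethyl compounds, which leaves the expectation loose.

No shift beyond the scatter is expected, and the expected step is a 1.2-fold higher number from compound 3 to compound 4 (0.06 log units; within the scatter) in this assay. For compound 4 the estimated value is 30 mL.min-1.g-1, with an expected range of 13 mL.min-1.g-1 to 65 mL.min-1.g-1.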

Compound 4, intrinsic clearance in microsomes: > 100 mL.min-1.g-1
Compound 4: only a limit was reported; the forecaster's own chance of this, stated with the estimate: 2%; at least 3.3-fold (0.52 log units) between middle value and limit.
By their numbers in this assay, from the lowest: compounds 2 and 3 (each within the scatter of the next); then compound 1. At a limit, above all of these: compound 4.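

Compound 4 stands at a limit of the assay, not at a number: the limit of > 100 mL.min-1.g-1 in this assay, at which 1 of the 4 values shown sits. In this assay, within the data shown here, this aryl group on the sulfonyl sulfur now shows a step beyond the scatter on the trifluoromethyl compounds: 3-chlorophenyl in place of 4-fluorophenyl gives an at least 3.8-fold higher number from compound 3 to compound 4 (0.58 log units; beyond the scatter), whereas the only earlier step here, fluoro in place of hydrogen, stayed within it at a 1.9-fold higher number from compound 2 to compound 3 (0.27 log units; within the scatter). Measured from the aryl group that carries no halogen, the step to the chlorine-bearing aryl group is an at least 7.1-fold higher number from compound 2 to compound 4 (0.85 log units; beyond the scatter), so the position can carry a large rise in clearance even though the earlier change did not show one.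

The compounds shown do not separate the chlorine from where it sits, which 4-chlorophenyl or 3-fluorophenyl on the trifluoromethyl core would address. On these data alone, how a nitrile or a methoxy group on this aryl ring would read also stays open.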